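Changing the aryl group on the amine nitrogen

A few compounds are considered here, and "the series" means these few. Any claim that something is new, unique, unknown or untested is made for them only; others in the source may bear on it.

Going by the values given here, in a functional assay on HeLa cells (Homo sapiens) for inhibition, read by sulforhodamine B assay (on this read-out higher numbers stand for weaker inhibition and lower numbers for stronger inhibition), compound 1 `O=C1C(Nc2ccccc2F)=CC(=O)c2c1nc1n2[C@H]2OC[C@@H](O)[C@H]2OC1` gives 9820 nM, and compound 2 `Cc1ccc(NC2=CC(=O)c3c(nc4n3[C@H]3OC[C@@H](O)[C@H]3OC4)C2=O)cc1C` gives 4320 nM, the lower of the two numbers so far. Compound 3 `CCOc1ccc(NC2=CC(=O)c3c(nc4n3[C@H]3OC[C@@H](O)[C@H]3OC4)C2=O)cc1` differs from compound 2 on the amine nitrogen: 4-ethoxyphenyl in place of 3,4-dimethylphenyl on an amine nitrogen. Among the compounds with values here, only one measured step bears on this place, a 2.3-fold lower number from compound 1 to compound 2 (0.36 log units; beyond the scatter), and it is modest. A change of similar modest size at most is therefore expected, with no firm direction. The expected step is a 1.1-fold higher number from compound 2 to compound 3 (0.05 log units; within the scatter). Compound 3 is estimated at 4800 nM, within an expected range of 2000 nM to 11000 nM.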

Compound 3, half-maximal inhibitory concentration: 14400 nM
The estimate for compound 3 lay 3.0-fold (0.48 log units) below the measured number; measured number above the stated range.
By their numbers in this assay, from the lowest: compound 2; then compounds 1 and 3 (each within the scatter of the next).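

In this assay the amine nitrogen proves sensitive in both directions: 4-ethoxyphenyl in place of 3,4-dimethylphenyl gives a 3.3-fold higher number from compound 2 to compound 3 (0.52 log units; beyond the scatter) and so loses what compound 2 had gained. In place of 2-fluorophenyl, the same group gives a 1.5-fold higher number from compound 1 to compound 3 (0.17 log units; within the scatter) and so only 3,4-dimethylphenyl stands apart among these three aryl groups. No measurement at hand accounts for these steps. Open, on these data alone, is whether a simple methyl or methoxy group on the phenyl ring would match compound 2, and whether a non-aromatic cyclohexyl group on the amine nitrogen would be tolerated.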